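Adding a Methyl to the Five-Membered Ring of Compound 2

The source may report more compounds than this note shows. Statements on the series, on what has been measured and on what is new or still open speak of the compounds shown alone.

Compound 1, `COC(=O)[C@@]1(C)CCC=C2[C@@H]1CC[C@@H](C)[C@]2(C)Cc1c[nH]c2ccccc12`: 3600 nM
Compound 2, `COC(=O)[C@@]1(C)CCC=C2[C@@H]1CC[C@@H](C)[C@]2(C)Cc1c[nH]c2c(C)cccc12`: 4900 nM
Compound 3, `COC(=O)[C@@]1(C)CCC=C2[C@@H]1CC[C@@H](C)[C@]2(C)Cc1c[nH]c2c(Br)cccc12`: 13000 nM

All three compounds share one core and were tested in a functional assay on HeLa cells (Homo sapiens) for inhibition, read by sulforhodamine B assay, with a stated time of 48 h; a higher number here means a weaker inhibitor of growth, a lower number a stronger inhibitor of growth. Compound 2 sits second highest of the three numbers: its value and that of compound 1 are within the scatter of each other, as a 1.4-fold higher number from compound 1 to compound 2 (0.13 log units; within the scatter) shows, while the gap to compound 3 is larger, as a 2.7-fold higher number from compound 2 to compound 3 (0.42 log units; beyond the scatter) shows. Compound 1 and compound 3 differ by a 3.6-fold higher number from compound 1 to compound 3 (0.56 log units; beyond the scatter).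

The unmeasured compound 4, `COC(=O)[C@@]1(C)CCC=C2[C@@H]1CC[C@@H](C)[C@]2(C)Cc1c(C)[nH]c2c(C)cccc12`, differs from compound 2 in one place: methyl in place of hydrogen on an aromatic carbon. Among the measured compounds shown here, the only measured step that adds the same group is a 1.4-fold higher number from compound 1 to compound 2 (0.13 log units; within the scatter), where a methyl replaced a hydrogen on an aromatic carbon of the six-membered ring; that step stayed within the scatter. The two bromo steps involve a different group and a different place, so they say little about a second methyl. On this basis the step from compound 2 to compound 4 in this assay is expected to be small, with no clear direction beyond the scatter; the expected step is a 1.2-fold higher number from compound 2 to compound 4 (0.09 log units; within the scatter). Compound 4 is therefore estimated at 6000 nM, with a range from 2500 nM to 15000 nM.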

Compound 4, concentration for 50% growth inhibition: 14000 nM
For compound 4 the middle estimate is 2.3-fold (0.37 log units) below the measured one; measured number inside the range.
By their numbers in this assay, from the lowest: compounds 1 and 2 (each within the scatter of the next); then compounds 3 and 4 (each within the scatter of the next).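

In this assay, putting a methyl on the aromatic carbon of the five-membered aromatic ring, next to the ring nitrogen and next to the ring atom that bears a large group, gives a 2.9-fold higher number from compound 2 to compound 4 (0.46 log units; beyond the scatter), which makes compound 4 a weaker inhibitor of growth than compound 2. Among the compounds shown here, the earlier methyl step, on the six-membered ring, gave a 1.4-fold higher number from compound 1 to compound 2 (0.13 log units; within the scatter), so only this new step shows that swapping hydrogen for methyl on an aromatic carbon of this series can go beyond the scatter, and that the same small change need not behave alike at every place. Nothing measured here accounts for the weaker inhibition at this carbon.

One step cannot tell whether any group at this carbon weakens growth inhibition or whether the result is specific to methyl, and an ethyl, a hydroxymethyl or an amine in the same place would help to separate the two. Going by these compounds, it also remains open whether this methyl would give a similar step on compound 1, which lacks the methyl on the six-membered ring.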